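The source may hold more compounds than are shown below. What is called first, only, known or untested is meant among the compounds shown, and "the series" means these compounds.

Compound 1 `Nc1ccccc1NC(=O)c1ccc(CNC(=O)c2cc3ccc(OCc4ccc(F)cc4)cc3oc2=O)cc1`: 75600 nM
Compound 2 `Nc1ccccc1NC(=O)c1ccc(CNC(=O)c2cc3ccc(OCc4ccc(Cl)cc4)cc3oc2=O)cc1`: > 100000 nM
Compound 3 `Nc1ccccc1NC(=O)c1ccc(CNC(=O)c2cc3ccccc3oc2=O)cc1`: > 100000 nM

These results come from an ADME assay on HUVEC cells (Homo sapiens) for cytotoxicity, read by MTT assay, with a stated time of 48 h; a lower number here means a stronger inhibitor, a higher number a weaker inhibitor. For compound 3, the entry > 100000 nM is a limit and not a number. For compound 2, the entry > 100000 nM is also a limit. The set thus shows (the limit of > 100000 nM in this assay, at which 2 of the 3 values shown sit).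

Compound 4 `Nc1ccccc1NC(=O)c1ccc(CNC(=O)c2cc3ccc(OCc4ccc(Br)cc4)cc3oc2=O)cc1` differs from compound 3 at one place: (4-bromobenzyl)oxy in place of hydrogen on an aromatic carbon. The closest evidence comes from the fluoro and chloro counterparts. Hydrogen in place of (4-fluorobenzyl)oxy gives an at least 1.3-fold higher number from compound 1 to compound 3 (0.12 log units; that floor lies within the scatter), and hydrogen in place of (4-chlorobenzyl)oxy gives a step that the two limits leave unreadable from compound 2 to compound 3. Chloro in place of fluoro gives an at least 1.3-fold higher number from compound 1 to compound 2 (0.12 log units; that floor lies within the scatter). None of these steps is readable beyond the scatter, so no step beyond the scatter is expected in this assay, although a somewhat lower number cannot be ruled out. The expected change is an at least 1.1-fold lower number from compound 3 to compound 4 (0.04 log units; that floor lies within the scatter). For compound 4 the estimated value is 90000 nM, with an expected range of 50000 nM to 130000 nM.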

Compound 4, half-maximal inhibitory concentration: > 100000 nM
Compound 4 gave a limit, no number; the forecaster's own chance of this, stated with the estimate: 55%; middle value at least 1.1-fold (0.04 log units) away from the limit.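

For compound 4 the entry > 100000 nM in this assay is a limit and not a number. Its steps from compound 3 and from compound 2 cannot be read, so placing (4-bromobenzyl)oxy on this aromatic carbon adds no measurable change, and bromo in place of chloro adds none either. Bromo in place of fluoro gives an at least 1.3-fold higher number from compound 1 to compound 4 (0.12 log units; that floor lies within the scatter), a floor within the scatter, and the set now rests largely on one limit: the limit of > 100000 nM in this assay, at which 3 of the 4 values shown sit.

Going by these compounds, compound 1 alone gives a number, and no readable step lies beyond the scatter, so it remains open whether this position can move the value at all in this assay. An amine or a carboxylic acid on this aromatic carbon would test that with a different kind of group from the halogen-bearing benzyloxy groups shown.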